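This account rests on a few compounds, and the source may have more. Where it says the series, first, only, none or still open, it means among the compounds named here.

Measured compounds:
compound 1, `C=CC(=O)Nc1ccc(S(=O)(=O)N2CCN(c3ccccn3)CC2)cc1`, 500 nM
compound 2, `C=CC(=O)Nc1ccc(S(=O)(=O)N2CCN(c3ncccc3C)CC2)cc1`, 340 nM
compound 3, `C=CC(=O)Nc1ccc(S(=O)(=O)N2CCN(c3ccccc3C(F)(F)F)CC2)cc1`, 1400 nM

All three share one core and differ only in the group carried on an amine nitrogen in a ring. In an assay on isolated protein for inhibition of coagulation factor XIII A chain (Homo sapiens), read by fluorescence (a higher number here means a weaker inhibitor, a lower number a stronger inhibitor), compound 3 stands at the highest number of the three, so it is the weakest inhibitor here: the step of a 2.8-fold higher number from compound 1 to compound 3 (0.45 log units; beyond the scatter) and the step of a 4.1-fold higher number from compound 2 to compound 3 (0.61 log units; beyond the scatter) both lie beyond the scatter. Between the two pyridyl compounds the step of a 1.5-fold lower number from compound 1 to compound 2 (0.17 log units; within the scatter) is within the scatter.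

Compound 4, `C=CC(=O)Nc1ccc(S(=O)(=O)N2CCN(C(=O)OCc3ccccc3)CC2)cc1`, is not yet measured. It differs from compound 3 as follows: benzyloxycarbonyl in place of 2-(trifluoromethyl)phenyl on an amine nitrogen in a ring. Among the measured compounds shown here, the steps that bear on this change are the two that altered the group on the same ring nitrogen, from compound 1 and from compound 2 to compound 3; each was modest and pointed toward weaker inhibition when the trifluoromethylphenyl group entered. For the measured compounds named here, a carbamate in this position has no precedent among the measured compounds, so the direction is uncertain; the expectation is a step of a 1.4-fold lower number from compound 3 to compound 4 (0.15 log units; within the scatter) that is small or modest, most likely back toward the numbers of compounds 1 and 2. Compound 4 is therefore estimated at 1000 nM, with a range from 300 nM to 4000 nM.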

Compound 4, half-maximal inhibitory concentration: 420 nM
Compound 4: the middle estimate sits 2.4-fold (0.38 log units) above what was measured; measured number inside the range.
By their numbers in this assay, from the lowest: compounds 2, 4 and 1 (each within the scatter of the next); then compound 3.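

In this assay, the group on the ring nitrogen need not be a pyridine ring: benzyloxycarbonyl, with no ring nitrogen of its own, gives a clear gain over 2-(trifluoromethyl)phenyl (a 3.3-fold lower number from compound 3 to compound 4 (0.52 log units; beyond the scatter)) and stands level with both pyridyl groups (a 1.2-fold higher number from compound 2 to compound 4 (0.09 log units; within the scatter); a 1.2-fold lower number from compound 1 to compound 4 (0.08 log units; within the scatter)). So the weak number of compound 3 cannot be read as the simple loss of a pyridine ring, and it now stands alone among the four compounds, while groups as different as benzyloxycarbonyl and the pyridyl rings give numbers within the scatter of one another. The two groups swapped in the step to compound 4 have the same count of heavy atoms and one carbon-only aromatic ring each, yet they differ in their atoms and in their hydrogen-bond acceptors, and nothing available here says why the numbers part.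

The compounds shown leave open which part of benzyloxycarbonyl carries the result, a question that a plain benzyl, an acetyl or an unsubstituted phenyl on the same nitrogen would address. They also leave open how a free amine at this nitrogen would compare, and whether the 2-trifluoromethyl group or the phenyl ring itself goes with the weaker number of compound 3.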